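Compound 1 and Compound 3: Expecting Little Movement

The compounds below may be only part of what the source reports. "The series", "measured", "known", "first", "only" and "open" are said of these compounds alone.

Compound 1 `COc1cc(Cl)cc(-c2nn(-c3cccc(NC(=O)Nc4ccc(Cl)c(C(F)(F)F)c4)c3)cc2-c2ccncc2)c1` gives 98% in a functional assay on NCI-H322M cells (Homo sapiens) for inhibition, read by sulforhodamine B assay, with a stated time of 48 h, tested at 0.1 uM; a lower number here means a stronger effect, a higher number a weaker effect of the compound at the concentration tested.
Compound 2 `COc1cc(Cl)cc(-c2nn(-c3cccc(NC(=O)Nc4cc(C(F)(F)F)cc(C(F)(F)F)c4)c3)cc2-c2ccncc2)c1` gives 95% in this assay.

Both numbers sit close to the top of the scale, meaning the cells were barely affected at the concentration tested. Compound 1 holds the highest of the two numbers, and compound 2 is only a few points away, which is within the usual scatter, so the two cannot be ranked against each other.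

Compound 3 `COc1cc(Cl)cc(-c2nn(-c3cccc(NC(=O)c4cccc(C(F)(F)F)c4)c3)cc2-c2ccncc2)c1` has not yet been measured. It differs from compound 1 by 3-(trifluoromethyl)phenyl in place of (4-chloro-3-(trifluoromethyl)phenyl)amino on a carbonyl carbon. Among the compounds with values here, no pair of measured compounds shows what such a change does here, so the expectation rests only on the weak effect seen for compound 1 and compound 2. The step from compound 1 to compound 3 is expected to be no larger than the scatter, a number 4 percentage points lower from compound 1 to compound 3 (within the scatter). Compound 3 is therefore estimated at 94%, with a range from 80% to 104%.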

Compound 3, a percentage reported as activity, at one concentration (the size of the read-out at that concentration, not a potency): 95%
The estimate for compound 3 lay 1 percentage points below the measured number; measured number inside the range.
By their numbers in this assay, from the lowest: compounds 2, 3 and 1 (each within the scatter of the next).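

In this assay, putting 3-(trifluoromethyl)phenyl in place of (4-chloro-3-(trifluoromethyl)phenyl)amino on a carbonyl carbon gives a number 3 percentage points lower from compound 1 to compound 3 (within the scatter). At this position, then, the amino nitrogen with its hydrogen-bond donor and the chlorine on the ring can both go without the read-out leaving the scatter, although all the numbers stay near the top of the scale, where the cells are barely affected, so this says little about how these groups would count in a compound with a clear effect. No outside measurement bears on this result.

Still open, as far as these compounds go, is whether any group on this carbonyl carbon can bring the number clearly down at this single concentration. An amine or a longer chain in place of the aromatic ring would test that, and a comparison at a higher concentration might separate these three compounds.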